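A Triazolylmethyl Arm Exchanged for a Chlorophenylethenyl Arm

The compounds below may be only part of what the source reports. "The series", "measured", "known", "first", "only" and "open" are said of these compounds alone.

Two sulfonamide-bearing compounds share one core and differ in a single arm. Compound 1 `NS(=O)(=O)c1cc(-c2nnc(CN3CCN(Cc4ccccc4)CC3)o2)c(Cl)cc1SCc1ccccc1` carries a benzylpiperazinylmethyl arm, and in a functional assay on HCT-116 cells (Homo sapiens) for cytotoxicity, read by MTT assay, with a stated time of 72 h (on this read-out lower numbers stand for stronger inhibition and higher numbers for weaker inhibition), compound 1 gives 26000 nM. Compound 2 `NC(=O)c1cn(Cc2nnc(-c3cc(S(N)(=O)=O)c(SCc4ccccc4)cc3Cl)o2)nn1` carries a (4-carbamoyl-1H-1,2,3-triazol-1-yl)methyl arm instead, and in this assay compound 2 gives 72000 nM, the highest of the two numbers; compound 1 lies lower by a margin that is beyond the usual scatter. Both compounds are weak in this assay.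

Compound 3 `NS(=O)(=O)c1cc(-c2nnc(/C=C/c3ccc(Cl)cc3)o2)c(Cl)cc1SCc1ccccc1` has not been measured. It differs from compound 2 as follows: 2-(4-chlorophenyl)ethenyl in place of (4-carbamoyl-1H-1,2,3-triazol-1-yl)methyl on an aromatic carbon. Among the measured compounds shown here, no measured pair in this set shows the effect of such a change, so the expectation rests only on the two values in hand, which lie close together and both far from strong inhibition. The step of a 2.4-fold lower number from compound 2 to compound 3 (0.38 log units; beyond the scatter) is expected to be a modest move toward lower numbers, near the edge of the scatter. Compound 3 is therefore expected to give about 30000 nM in this assay, with a likely range from 10000 nM to 90000 nM.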

Compound 3, half-maximal inhibitory concentration: 12000 nM
For compound 3 the middle estimate is 2.5-fold (0.40 log units) above the measured one; measured number inside the range.
By their numbers in this assay, from the lowest: compound 3; then compound 1; then compound 2.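

In this assay, the exchange on the aromatic carbon of the five-membered aromatic ring with 2 nitrogen and 1 oxygen gives a 6.0-fold lower number from compound 2 to compound 3 (0.78 log units; beyond the scatter) and so shows that the number responds to what stands at this place. Both arms have 9 heavy atoms and 1 double bond outside aromatic rings, so the step arises without a change in either count. It comes instead with the loss of the 1 hydrogen-bond donor and 4 hydrogen-bond acceptors of the leaving arm and the arrival of a six-membered aromatic ring of carbon only bearing chlorine, though no measurement on hand explains the step.

The compounds shown do not separate the contribution of the chlorine from that of the ethenyl link, a question that a plain 2-phenylethenyl arm and a saturated 2-(4-chlorophenyl)ethyl arm could address. From the compounds shown here alone, it also remains open how the number would respond to an amine or a carboxylic acid on the ring of this arm, or to a longer chain in place of the ethenyl link.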